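Two inverted stereocentres in a hydroxylated ring acid

The source may report more compounds than this note shows. Statements on the series, on what has been measured and on what is new or still open speak of the compounds shown alone.

Measured so far:
compound 1 `O=C(O)[C@H]1NC[C@H](O)[C@H](O)[C@@H]1O`, 4.5%
compound 2 `O=C(O)[C@H]1NC[C@H](O)[C@@H](O)[C@@H]1O`, 0.2%

In an assay for inhibition of alpha-N-acetylgalactosaminidase (Gallus gallus), tested at 1000 uM (a lower number here means less inhibition, a higher number more inhibition at the concentration tested (going by the name of the read-out)), compound 1 stands at 4.5% and compound 2 at 0.2%, the two within the usual scatter of each other; the step of a number 4.3 percentage points lower from compound 1 to compound 2 (within the scatter) is small. That step rests on (the fact that compounds 1 and 2 differ only in the configuration as drawn). Compound 3 `O=C(O)[C@H]1NC[C@H](O)[C@@H](O)[C@H]1O` is related to compound 1 by the two compounds have the same atoms and bonds and differ only in configuration as drawn: 2 of 4 stereo elements differ; a stereocentre at a saturated ring carbon is drawn S in compound 1 and R in compound 3; a stereocentre at a saturated ring carbon is drawn R in compound 1 and S in compound 3. Among the measured compounds shown here, only the step from compound 1 to compound 2 bears on this change, and it stayed within the scatter, so no step beyond the scatter is expected in this assay. The expected step is a number 1.5 percentage points lower from compound 1 to compound 3 (within the scatter). Compound 3 is therefore estimated at 3%, ranging from 0% to 12%.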

Compound 3, a percentage reported as inhibition, at one concentration (the size of the read-out at that concentration, not a potency): 31%
The estimate for compound 3 lay 28 percentage points below the measured number, and the stated range ends below it.
By their numbers in this assay, from the lowest: compounds 2 and 1 (each within the scatter of the next); then compound 3.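

In this assay, configuration alone now moves the number: inverting one stereocentre at a saturated ring carbon, drawn R before and S after, gives a number 30.8 percentage points higher from compound 2 to compound 3 (beyond the scatter). With two stereocentres changed, the result is a number 26.5 percentage points higher from compound 1 to compound 3 (beyond the scatter), whereas the single inversion seen earlier stayed within the scatter, so among these compounds the outcome depends on which ring carbon is inverted. No group enters or leaves, so these steps rest on configuration alone: the fact that compounds 2 and 3 differ only in the configuration as drawn

The compounds shown leave open how the other two stereocentres behave. They also leave open whether an amide or a hydroxymethyl group in place of the carboxylic acid would keep this inhibition.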